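Acylurea aryl swap on an inactive hydrazone parent

The source may report more compounds than this note shows. Statements on the series, on what has been measured and on what is new or still open speak of the compounds shown alone.

Compound 1 `CN(C(=O)NC(=O)c1ccc(C(F)(F)F)cc1)c1nc(C(F)(F)F)c(C(=O)N/N=C/c2ccc(C(F)(F)F)cc2)s1` is measured in a functional assay on HeLa cells (Homo sapiens) for inhibition, read by MTT assay, with a stated time of 72 h (a higher number here means a weaker inhibitor, a lower number a stronger inhibitor), only as a limit, giving > 100 ug/mL; no number is known for it. Among the compounds with values here, compound 2 `CN(C(=O)NC(=O)c1ccc(C(F)(F)F)cc1)c1nc(C(F)(F)F)c(C(=O)N/N=C/c2cccc(C(F)(F)F)c2)s1` gives 6.2 ug/mL in this assay, and the step of an at least 16-fold lower number from compound 1 to compound 2 (1.20 log units; beyond the scatter) is the one measured step, concerning the aryl group on the carbon with a double bond to nitrogen. Compound 3 `CN(C(=O)NC(=O)c1ccccc1F)c1nc(C(F)(F)F)c(C(=O)N/N=C/c2ccc(C(F)(F)F)cc2)s1` differs from compound 1 at another place: 2-fluorophenyl in place of 4-(trifluoromethyl)phenyl on a carbonyl carbon. No measured step touches this position, so the change is unsupported by any shown pair, and the parent compound 1 sits at the limit (the limit of > 100 ug/mL in this assay, at which 1 of the 2 values shown sits). Compound 3 is therefore expected to stay near that limit, with the step of a number no higher from compound 1 to compound 3 (the limit leaves the size open) estimated as none beyond the scatter. Compound 3 is estimated at 100 ug/mL, within 30 ug/mL to 300 ug/mL, and a second limit rather than a number is expected as likely.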

Compound 3, half-maximal inhibitory concentration: 3.97 ug/mL
For compound 3 the middle estimate is 25-fold (1.40 log units) above the measured one; the measured number lies below the stated range.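

The carbonyl carbon turns out to be a position that responds: in this assay, 2-fluorophenyl in place of 4-(trifluoromethyl)phenyl gives an at least 25-fold lower number from compound 1 to compound 3 (1.40 log units; beyond the scatter) on the shared core. Compound 1 is only a limit, so the true size of this step stays unfixed: the limit of > 100 ug/mL in this assay, at which 1 of the 3 values shown sits. Compound 3 keeps the 4-(trifluoromethyl)phenyl on the carbon with a double bond to nitrogen, so that group does not by itself hold the series at the limit, and the aryl group on that carbon is no longer the only place where a single change gives a large step.

Still open, going by these compounds, is whether the step comes from gaining 2-fluorophenyl or from losing 4-(trifluoromethyl)phenyl, and how 2-fluorophenyl and 3-(trifluoromethyl)phenyl would read together in one compound. Also open, on these data alone, is how a plain phenyl, or a phenyl carrying an amine or a carboxylic acid, would read on the carbonyl carbon.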